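The source may report more compounds than this note shows. Statements on the series, on what has been measured and on what is new or still open speak of the compounds shown alone.

Working notes on the series. Compound 1 `Cc1ccc(NC(=S)NC(=O)c2ccc(OCc3ccc(C(F)(F)F)cc3)cc2)cc1-c1nc2ccccc2[nH]1` and compound 2 `Cc1ccc(NC(=S)NC(=O)c2ccc(OCc3cccc(C(F)(F)F)c3)cc2)cc1-c1nc2ccccc2[nH]1` share one core; compound 3 `Cc1ccc(NC(=O)NC(=O)c2ccc(OCc3ccc(C(F)(F)F)cc3)cc2)cc1-c1nc2ccccc2[nH]1` and compound 4 `Cc1ccc(NC(=O)NC(=O)c2ccc(OCc3cccc(C(F)(F)F)c3)cc2)cc1-c1nc2ccccc2[nH]1` share another. How the core of compound 3 differs from the core of compound 1 is not broken down here. In a functional assay on MGC-803 cells (Homo sapiens) for inhibition, read by MTT assay, with a stated time of 48 h (on this read-out higher numbers stand for weaker inhibition and lower numbers for stronger inhibition), compound 1 gives 6500 nM, and compound 2 gives 5210 nM. The change between them, (3-(trifluoromethyl)phenyl in place of 4-(trifluoromethyl)phenyl on a saturated chain carbon bound to an oxygen on an aromatic ring), produced a 1.2-fold lower number from compound 1 to compound 2 (0.10 log units; within the scatter). In this assay compound 3 gives 14900 nM, the highest number among the three measured compounds, with its gaps to both compound 1 and compound 2 beyond the scatter. Compound 4 has not yet been measured. It differs from compound 3 by 3-(trifluoromethyl)phenyl in place of 4-(trifluoromethyl)phenyl on a saturated chain carbon bound to an oxygen on an aromatic ring, the same change as that from compound 1 to compound 2, made at the same place. Among the compounds with values here, the step expected from compound 3 to compound 4 in this assay is a 1.2-fold lower number from compound 3 to compound 4 (0.08 log units; within the scatter), set beside the earlier step because a 1.2-fold lower number from compound 1 to compound 2 (0.10 log units; within the scatter) lay within the scatter and no measured pair suggests the second core responds differently to this change. For compound 4 the estimated value in this assay is 12400 nM, expected to fall between 7000 nM and 22000 nM.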

Compound 4, half-maximal inhibitory concentration: 13100 nM
Beside the measured number, compound 4's estimate is 1.1-fold (0.02 log units) below it; measured number inside the range.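

In this assay, 3-(trifluoromethyl)phenyl in place of 4-(trifluoromethyl)phenyl on a saturated chain carbon bound to an oxygen on an aromatic ring gives a 1.1-fold lower number from compound 3 to compound 4 (0.06 log units; within the scatter). The change reads the same on the two cores: the same change on two cores in this assay, a 1.2-fold lower number (0.10 log units; within the scatter) from compound 1 to compound 2 and a 1.1-fold lower number (0.06 log units; within the scatter) from compound 3 to compound 4, 1.1-fold (0.04 log units) apart, within the scatter of two such steps. Within the data shown here, this shows only that a step within the scatter on the core of compound 1 also stays within the scatter on the core of compound 3; it does not show that a step beyond the scatter would carry over, or that the agreement would hold on a third core or in another cell line.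

The compounds shown leave open how this part of the series responds when trifluoromethyl gives way to a different group, such as a nitrile, a methoxy group or a chlorine. Also open, as far as these compounds go, is whether a longer chain carrying the 3-(trifluoromethyl)phenyl group, or an amine or a carboxylic acid on that ring, would move the number beyond the scatter on either core.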